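A Bromo Shift Across the Shared Core of Compound 1

The source may hold more compounds than are shown below. What is called first, only, known or untested is meant among the compounds shown, and "the series" means these compounds.

Compound 1 `O=C1NC[C@@H](c2c[nH]c3ccccc23)N[C@H]1c1c[nH]c2ccccc12` is the parent of this small set. Going by the values given here, in an ADME assay on SK-OV-3 cells (Homo sapiens) for cytotoxicity (a higher number here means that more compound is needed for the effect, a lower number that less compound is needed), compound 1 gives 9.64 ug/mL, the highest of the two numbers measured so far. Among the compounds with values here, its only measured neighbour is compound 2 `O=C1NC[C@@H](c2c[nH]c3cc(Br)ccc23)N[C@H]1c1c[nH]c2ccccc12`, which carries a bromo group; in this assay compound 2 gives 6 ug/mL, and the step of a 1.6-fold lower number from compound 1 to compound 2 (0.21 log units; within the scatter) lies within the scatter. Compound 3 `O=C1NC[C@@H](c2c[nH]c3ccccc23)N[C@H]1c1c[nH]c2cc(Br)ccc12` differs from compound 1 by bromo in place of hydrogen on an aromatic carbon. Within the data shown here, the one step that bears on this change is the bromo step from compound 1 to compound 2, which was within the scatter; the same group now enters at a different place on the shared core. No step beyond the scatter is therefore expected, and the estimated step is a 1.4-fold lower number from compound 1 to compound 3 (0.14 log units; within the scatter). For compound 3 the expected value in this assay is 7 ug/mL, with a range from 3.5 ug/mL to 14 ug/mL.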

Compound 3, concentration for half-maximal effect: 5.67 ug/mL
Beside the measured number, compound 3's estimate is 1.2-fold (0.09 log units) above it; measured number inside the range.
By their numbers in this assay, from the lowest: compounds 3, 2 and 1 (each within the scatter of the next).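

In this assay, the step for bromo in place of hydrogen at this new place, on an aromatic carbon of a six-membered aromatic ring of carbon only, is also within the scatter (a 1.7-fold lower number from compound 1 to compound 3 (0.23 log units; within the scatter)). Taken with the earlier step (a 1.6-fold lower number from compound 1 to compound 2 (0.21 log units; within the scatter)), it shows that in these compounds bromo gives no step beyond the scatter at either of the two places tried on the shared core. No available evidence bears on this result.

On these data alone, it remains open whether a different group at this place, such as an amine, a carboxylic acid or a longer chain, would give a step beyond the scatter. Also open, as far as these compounds go, is what bromo at both places on the core of compound 1 would give in this assay.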